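The source may hold more compounds than are shown below. What is called first, only, known or untested is meant among the compounds shown, and "the series" means these compounds.

Compound 1 `O=C(Oc1ccc(-c2ccc(F)cc2F)cc1C(=O)O)c1ccccc1`: 16.1%
Compound 2 `CCNC(=O)c1cc(-c2ccc(F)cc2F)ccc1OC(C)=O`: 5.38%
Compound 3 `CC(=O)Oc1ccc(-c2ccc(F)cc2F)cc1C(=O)NC1CCCCC1`: 0%

In a functional assay on the whole organism (Ear) for inhibition, with Mus musculus as the target, at a dose of 40 mg/kg by the oral route (a lower number here means less inhibition, a higher number more inhibition at the dose given (going by the name of the read-out)), compound 3 gives 0%. This number lies within the scatter of the number for compound 2 and apart from that of compound 1 only. Compound 4 `CC(=O)Oc1ccc(-c2ccc(F)cc2F)cc1C(=O)Nc1ccccc1C` differs from compound 3 in one place: 2-methylphenyl in place of cyclohexyl on an amide-type nitrogen. For the measured compounds named here, only one measured step touches this amide-type nitrogen, namely a number 5.4 percentage points lower from compound 2 to compound 3 (within the scatter), which stayed within the scatter, and no measured pair shows an aromatic ring taking the place of cyclohexyl. On this basis the step from compound 3 to compound 4 is expected to be a number 3 percentage points higher from compound 3 to compound 4 (within the scatter), that is, no change beyond the scatter. Compound 4 is therefore estimated at 3%, with a range from 0% to 12%.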

Compound 4, a percentage reported as inhibition, in the whole organism at one dose (the size of the read-out at that dose, not a potency): 19.6%
Compound 4: the middle estimate sits 16.6 percentage points below what was measured, outside the stated range (above it).
By their numbers in this assay, from the lowest: compounds 3 and 2 (each within the scatter of the next); then compounds 1 and 4 (each within the scatter of the next).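

At this amide-type nitrogen, the swap of ethyl for cyclohexyl had stayed within the scatter, so the group seemed to matter little in this assay. 2-Methylphenyl changes that picture, with a number 19.6 percentage points higher from compound 3 to compound 4 (beyond the scatter) and a number 14.2 percentage points higher from compound 2 to compound 4 (beyond the scatter), both beyond the scatter. Nothing measured here explains this rise.

Whether the aromatic ring or its methyl accounts for the steps remains open. Plain phenyl on this nitrogen would separate the two, and a longer chain such as hexyl would test whether ring-free groups stay low.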